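The source may report more compounds than this note shows. Statements on the series, on what has been measured and on what is new or still open speak of the compounds shown alone.

Values in a functional assay on OVCAR-8 cells (Homo sapiens) for antiproliferative activity; a lower number here means a stronger inhibitor, a higher number a weaker inhibitor:
- compound 1 `Cn1ncc(Cl)c1-c1cc(C(=O)N[C@@H]2CN[C@H](CC(O)CO)C[C@H]2c2ccc(F)c(F)c2)oc1Cl` gives 690 nM
- compound 2 `Cn1ncc(Cl)c1-c1cc(C(=O)N[C@@H]2CN[C@H](CCO)C[C@H]2c2ccc(F)c(F)c2)oc1Cl` gives 460 nM
- compound 3 `CNC(=O)C[C@@H]1C[C@@H](c2ccc(F)c(F)c2)[C@H](NC(=O)c2cc(-c3c(Cl)cnn3C)c(Cl)o2)CN1` gives 800 nM

Compound 3 stands within the scatter of both compound 1 and compound 2, so no order can be read among the three. The remaining step, a 1.5-fold lower number from compound 1 to compound 2 (0.18 log units; within the scatter), also stays within the scatter. The change to compound 4 `CC(=O)OCC[C@@H]1C[C@@H](c2ccc(F)c(F)c2)[C@H](NC(=O)c2cc(-c3c(Cl)cnn3C)c(Cl)o2)CN1` is acetoxymethyl in place of methylcarbamoyl on a saturated chain carbon bound to a saturated ring carbon. For the measured compounds named here, the steps that bear on it are a 1.2-fold higher number from compound 1 to compound 3 (0.06 log units; within the scatter) and a 1.7-fold higher number from compound 2 to compound 3 (0.24 log units; within the scatter), both made at this same place and both within the scatter. Going by the values given here, no measured compound carries the acetoxymethyl group, so this is an extrapolation and the range is kept wide. No shift beyond the scatter is expected in this assay, and no direction is firmly favoured. The expected step is a 1.3-fold lower number from compound 3 to compound 4 (0.12 log units; within the scatter). For compound 4 the estimate is 600 nM, with an expected range of 270 nM to 1300 nM.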

Compound 4, half-maximal inhibitory concentration: 4960 nM
Beside the measured number, compound 4's estimate is 8.3-fold (0.92 log units) below it; the whole stated range lies below it.
By their numbers in this assay, from the lowest: compounds 2, 1 and 3 (each within the scatter of the next); then compound 4.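

The side chain on the saturated ring carbon had looked tolerant in this assay, but that tolerance does not extend to acetoxymethyl (a 6.2-fold higher number from compound 3 to compound 4 (0.79 log units; beyond the scatter)). The ester also stands apart from the 1,2-dihydroxyethyl chain (a 7.2-fold higher number from compound 1 to compound 4 (0.86 log units; beyond the scatter)), and acetyl in place of hydrogen on the oxygen of the hydroxyl-ending chain alone gives a large step (an 11-fold higher number from compound 2 to compound 4 (1.03 log units; beyond the scatter)). So the hydroxyl-bearing chains and methylcarbamoyl sit within the scatter of one another, while this single capped oxygen, with hydrogen-bond donors going from 1 to 0 against methylcarbamoyl, moves the number well beyond it.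

Still open, as far as these compounds go, is whether a methyl ether, an amine or a carboxylic acid at the same chain end would stay with the first three compounds or follow compound 4. Nothing at hand gives a reason for the step.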